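A few compounds are considered here, and "the series" means these few. Any claim that something is new, unique, unknown or untested is made for them only; others in the source may bear on it.

In a functional assay on HepG2 cells (Homo sapiens) for cytotoxicity, read by MTT assay, with a stated time of 24 h (on this read-out higher numbers stand for weaker inhibition and lower numbers for stronger inhibition), compound 1 `COc1ccc(/C=C2\CN(C)C/C(=C\c3ccccc3F)C2=O)cc1OC` gives 8760 nM while compound 2 `COc1cc(/C=C2\CN(C)C/C(=C\c3ccccc3F)C2=O)cc(OC)c1` gives 1240 nM and compound 3 `COc1cc(/C=C2\CN(C)C/C(=C\c3ccccc3F)C2=O)cc(OC)c1OC` gives 670 nM in this small set. Methoxy in place of hydrogen on an aromatic carbon brings a 13-fold lower number from compound 1 to compound 3 (1.12 log units; beyond the scatter) but only a 1.9-fold lower number from compound 2 to compound 3 (0.27 log units; within the scatter) in the second case. Compound 3 therefore sits with compound 2 at the low end, far from compound 1. Compound 4 `COc1cc(/C=C2\CN(C)C/C(=C\c3cc(OC)c(OC)c(OC)c3)C2=O)cc(OC)c1` carries 3,5-dimethoxyphenyl in place of 2-fluorophenyl on a double-bonded chain carbon bound to a double-bonded ring carbon. Neither measured step touches that 2-fluorophenyl, so they offer only weak guidance, showing that methoxy changes elsewhere can matter greatly or hardly at all. A modest move toward a higher number is expected in this assay, as the estimated 2.2-fold higher number from compound 3 to compound 4 (0.35 log units; beyond the scatter) indicates. Compound 4 is estimated at 1500 nM (range 400 nM to 6000 nM).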

Compound 4, half-maximal inhibitory concentration: 890 nM
Estimate against measurement, compound 4: 1.7-fold (0.23 log units) above, and the stated range covers the measured number.
By their numbers in this assay, from the lowest: compounds 3, 4 and 2 (each within the scatter of the next); then compound 1.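

In this assay, 3,5-dimethoxyphenyl in place of 2-fluorophenyl gives a 1.3-fold higher number from compound 3 to compound 4 (0.12 log units; within the scatter) and so makes no clear difference. This position on a double-bonded chain carbon bound to a double-bonded ring carbon therefore accepts this larger group, which has no fluorine, with the number staying within the scatter. One swap cannot show how far that tolerance extends.

From the compounds shown here alone, whether an amine or a carboxylic acid on this aromatic ring would also leave the number unchanged stays open, as does the effect of a longer chain in place of the ring. No evidence here explains why the swap changes so little.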